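The compounds below may be only part of what the source reports. "The series", "measured", "known", "first", "only" and "open" are said of these compounds alone.

Measured so far:
compound 1 `COc1ccc2c(c1)OC(c1cc(OC)c(OC)c(OC)c1)C(C(=O)N(C)OC)=C2`, 11700 nM in a functional assay for inhibition of nuclear factor NF-kappa-B complex (Homo sapiens); on this read-out lower numbers stand for stronger inhibition and higher numbers for weaker inhibition
compound 2 `COc1ccc2c(c1)OC(c1cc(OC)c(OC)c(OC)c1)C(C=O)=C2`, 13500 nM in this assay

Within the data shown here, of the two numbers in hand, compound 2 and compound 1 lie within the scatter of each other; the one step measured so far, a 1.2-fold higher number from compound 1 to compound 2 (0.06 log units; within the scatter), is hydrogen in place of methoxy(methyl)amino on the carbonyl carbon and does not move the read-out beyond the usual spread. Compound 2 is therefore not separated from compound 1 on this read-out.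

Compound 3 `COc1ccc2c(c1)OC(c1cc(OC)c(OC)c(OC)c1)C(C(=O)OCCc1ccccc1)=C2` differs from compound 2 by phenethyloxy in place of hydrogen on a carbonyl carbon. Among the measured compounds shown here, no measured pair shows this change, or any ester at that carbonyl carbon. For the measured compounds named here, the single step that bears on the carbonyl substituent, a 1.2-fold higher number from compound 1 to compound 2 (0.06 log units; within the scatter), shows that swapping the group on this carbonyl carbon between an amide and a hydrogen leaves the number within the scatter. On that basis alone, the step to a phenethyl ester is expected to stay in the same range, with no direction beyond the scatter, and the expected step is a 1.1-fold lower number from compound 2 to compound 3 (0.05 log units; within the scatter). Compound 3 is thus estimated at 12000 nM, within the range 5000 nM to 30000 nM.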

Compound 3, half-maximal inhibitory concentration: 16200 nM
Beside the measured number, compound 3's estimate is 1.4-fold (0.13 log units) below it; measured number inside the range.
By their numbers in this assay, from the lowest: compounds 1, 2 and 3 (each within the scatter of the next).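

In this assay the carbonyl carbon on the double-bonded ring carbon now carries an ester as well as an amide and a hydrogen, and the read-out does not separate the three. Phenethyloxy in place of hydrogen gives a small step (a 1.2-fold higher number from compound 2 to compound 3 (0.08 log units; within the scatter)), and phenethyloxy in place of methoxy(methyl)amino also stays inside the usual spread (a 1.4-fold higher number from compound 1 to compound 3 (0.14 log units; within the scatter)). The entering group brings a six-membered aromatic ring of carbon only, so this position has now taken a substituent with an aromatic ring with no step beyond the scatter, though no measurement here offers an explanation for that.

Still open, on these data alone, is whether any group on this carbonyl carbon can move the number beyond the scatter, for instance a carboxylic acid, an amide carrying an amine on a longer chain, or an ester without the phenyl ring. The compounds shown also share one core with all its methoxy groups, so they leave open how the number responds to a change anywhere other than this carbonyl carbon.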